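The compounds below may be only part of what the source reports. "The series", "measured", "known", "first", "only" and "open" are said of these compounds alone.

Of the compounds shown here, three sharing one core have been tested in a functional assay on HT cells (Homo sapiens) for antiproliferative activity, read by fluorescence, with a stated time of 72 h; a lower number here means a stronger inhibitor of growth, a higher number a weaker inhibitor of growth. There, compound 1 `CC(C)c1n[nH]c2c(NCc3ccc(-c4ccccn4)cc3)nc(SCC(O)CO)nc12` gives 21 nM, compound 2 `CC(C)c1n[nH]c2c(NCc3ccc(-c4ccccn4)cc3)nc(SCCO)nc12` gives 48 nM, and compound 3 `CC(C)c1n[nH]c2c(NCc3ccc(-c4ccccn4)cc3)nc(SCC(O)C(F)(F)F)nc12` gives 690 nM, the highest number of the three and so the weakest inhibitor of growth in this small set. Compound 4 `CC(C)c1n[nH]c2c(NCc3ccc(-c4ccccn4)cc3)nc(SCC(O)CN3CCNCC3)nc12` has not yet been measured. It keeps everything in compound 3 except one group, with (piperazin-1-yl)methyl in place of trifluoromethyl on a saturated chain carbon bound to an oxygen on a saturated carbon and a saturated chain carbon.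

All three measured steps concern this same place. Hydrogen in place of hydroxymethyl gave only a modest change, a 2.3-fold higher number from compound 1 to compound 2 (0.36 log units; beyond the scatter). Trifluoromethyl gave large ones, a 33-fold higher number from compound 1 to compound 3 (1.52 log units; beyond the scatter) and a 14-fold higher number from compound 2 to compound 3 (1.16 log units; beyond the scatter). Among the measured compounds shown here, no tested compound carries the piperazine ring, so the data say nothing direct about it. Since trifluoromethyl alone goes with a large rise, losing it is expected to give a large fall in this assay, back towards compound 2 at 48 nM. The expected step is a 14-fold lower number from compound 3 to compound 4 (1.14 log units; beyond the scatter). For compound 4 the estimated value is 50 nM, with an expected range of 15 nM to 200 nM.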

Compound 4, concentration for 50% growth inhibition: 332 nM
Beside the measured number, compound 4's estimate is 6.6-fold (0.82 log units) below it; measured number outside the range, above it.
By their numbers in this assay, from the lowest: compound 1; then compound 2; then compound 4; then compound 3.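

Trifluoromethyl turns out not to be the only group at this place that goes with a high number in this assay: replacing it with (piperazin-1-yl)methyl recovers only a small part of the ground (a 2.1-fold lower number from compound 3 to compound 4 (0.32 log units; beyond the scatter)), far less than the return to the level of compound 2 that its removal alone might have allowed. The larger group still sits well short of the smaller ones, with hydrogen (a 6.9-fold higher number from compound 2 to compound 4 (0.84 log units; beyond the scatter)) and hydroxymethyl (a 16-fold higher number from compound 1 to compound 4 (1.20 log units; beyond the scatter)) both giving lower numbers, so the tolerance seen between compound 1 and compound 2 does not extend to every group placed here. Nothing available bears on why the piperazine ring costs this much.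

As far as these compounds go, what remains open is whether the high number of compound 4 goes with the ring as a whole or with its nitrogens, which a dimethylamino group or a primary amine at this place would help to separate. From the compounds shown here alone, it is also open how a carboxylic acid here would compare, or whether a longer chain carrying the piperazine ring would change the picture.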